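The compounds below may be only part of what the source reports. "The series", "measured", "known", "first", "only" and "open" are said of these compounds alone.

Compound 1 `COc1ccc(Nc2cc3c(cn2)ncn3CC2CC2)c(OC)c1`: 0.233 h
Compound 2 `Cc1cc(Nc2ccc(-n3ccnc3)nc2)nc2c1ncn2CC1CC1`: 0.667 h

Both numbers come from an ADME assay on microsomes from liver (Homo sapiens) for metabolic stability; a lower number here means that the compound disappears faster, a higher number that the compound lasts longer. Compound 2, at 0.667 h, stands highest of the two, and its gap to compound 1 lies beyond the usual scatter. These two compounds differ in more than one place, however, so their gap cannot be tied to any single change.

Compound 3 `Cc1c(F)c(Nc2ccc(-n3ccnc3)nc2)nc2c1ncn2CC1CC1` is compound 2 with one change: fluoro in place of hydrogen on an aromatic carbon. The new fluoro sits ortho to a methyl group. Going by the values given here, no measured pair shows what this swap does in this assay, so the expectation is cautious: a slight rise that stays within the scatter. The estimated move is a 1.2-fold higher number from compound 2 to compound 3 (0.08 log units; within the scatter). Compound 3 is expected at about 0.8 h, with an estimated range from 0.4 h to 1.6 h.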

Compound 3, half-life: > 1.66 h
Compound 3: only a limit was reported; the forecaster's own chance of this, stated with the estimate: 5%; at least 2.0-fold (0.31 log units) between middle value and limit.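

Swapping fluoro in place of hydrogen on an aromatic carbon, ortho to a methyl group and two atoms from the ring nitrogen, gives an at least 2.4-fold higher number from compound 2 to compound 3 (0.39 log units; beyond the scatter) in this assay and is the first gap here that can be tied to a single change. It shows that this position is sensitive in this measure, and that one added fluoro can be enough to move the half-life beyond the usual scatter. Compound 3 has only a limit, so the full size of the step remains unknown: the limit of > 1.66 h in this assay, at which 1 of the 3 values shown sits.

Whether this rise is specific to fluoro remains open, as no compound shown carries a chloro group or an amine at this carbon. Also open, from the compounds shown here alone, is whether the same swap would give a similar rise on the core of compound 1.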